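Acyl variation on the shared core in the writhing test

The source may report more compounds than this note shows. Statements on the series, on what has been measured and on what is new or still open speak of the compounds shown alone.

Among the measured compounds shown here, compound 1 `CC(=O)/N=C1\NC2(CCCCO2)CCS1` is the only compound of the series with a number in a functional assay on the whole organism (strain CF-1) with Mus musculus as the target, in the writhing test, with a stated time of 15 min (a higher number here means that more compound is needed for the effect, a lower number that less compound is needed), where compound 1 gives 3.1 mg/kg. Compound 2 `c1ccc(/N=C2\NC3(CCCCO3)CCS2)cc1` reaches only the limit > 200 mg/kg in this assay. The step of an at least 64-fold higher number from compound 1 to compound 2 (1.80 log units; beyond the scatter) ends at the limit of > 200 mg/kg in this assay, at which 1 of the 2 values shown sits. Compound 3 `O=C(/N=C1\NC2(CCCCO2)CCS1)c1ccco1` differs from compound 1 by furan-2-yl in place of methyl on a carbonyl carbon; the carbonyl stays, and only the group on it changes. For the measured compounds named here, no measured step covers this change; the single measured step removes the whole acetyl, so a smaller shift towards a higher number is expected here. Compound 3 is estimated at 8 mg/kg, between 2 mg/kg and 40 mg/kg, with the step of a 2.6-fold higher number from compound 1 to compound 3 (0.41 log units; beyond the scatter) expected.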

Compound 3, dose for half-maximal effect: 42 mg/kg
Estimate against measurement, compound 3: 5.3-fold (0.72 log units) below, and the stated range ends below it.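

In this assay there is a 14-fold higher number from compound 1 to compound 3 (1.13 log units; beyond the scatter) with the carbonyl kept, so the group on the carbonyl carbon counts on its own. The earlier step replaced the whole acetyl and could not separate the carbonyl from the methyl on it. Nothing measured here accounts for the size of this shift.

On these data alone, it remains open whether ethyl or a longer chain on the carbonyl carbon stays close to compound 1 or moves towards compound 3. As far as these compounds go, it also remains open whether another five-membered aromatic ring, such as thiophene, behaves like furan-2-yl.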